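A few compounds are considered here, and "the series" means these few. Any claim that something is new, unique, unknown or untested is made for them only; others in the source may bear on it.

In a functional assay on HeLa cells (Homo sapiens) for inhibition, read by CCK-8 assay, with a stated time of 72 h (a higher number here means a weaker inhibitor, a lower number a stronger inhibitor), compound 1 (`O=C(/C=C/c1cccnc1)NCCCCCc1cccc(S(=O)(=O)Nc2ccccc2)c1`) gives 105 nM and compound 2 (`Cc1ccc(NS(=O)(=O)c2cccc(CCCCCCNC(=O)/C=C/c3cccnc3)c2)cc1`) gives 38.8 nM as the lower of the two numbers, a gap beyond the usual scatter. These two compounds differ in more than one place and offer no single-change reading. Compound 3 (`O=C(/C=C/c1cccnc1)NCCCCCCc1cccc(S(=O)(=O)Nc2ccc(Cl)cc2)c1`) stands one change away from compound 2: chloro in place of methyl on an aromatic carbon (chloro in place of methyl on an aromatic carbon, para to a large group, reading as 4-methylphenyl to 4-chlorophenyl). Among the compounds with values here, no measured pair shows this change, and the data give no direction for it. The expectation is therefore no shift beyond the scatter in this assay, anchored on compound 2 at 38.8 nM as the nearest measured neighbour. The expected step of a 1.0-fold higher number from compound 2 to compound 3 (0.01 log units; within the scatter) stays within the scatter. For compound 3 the estimated value is 40 nM (expected range 15 nM to 110 nM).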

Compound 3, half-maximal inhibitory concentration: 170 nM
Compound 3: the middle estimate sits 4.3-fold (0.63 log units) below what was measured; measured number above the stated range.
By their numbers in this assay, from the lowest: compound 2; then compounds 1 and 3 (each within the scatter of the next).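

In this assay the change from 4-methylphenyl to 4-chlorophenyl (a 4.4-fold higher number from compound 2 to compound 3 (0.64 log units; beyond the scatter)) gives the series its first single-change reading. It shows that this position, para to a large group, is sensitive to the group it carries, and that chloro in place of methyl gives a weaker inhibitor in this pair, though this single pair sets the direction for these two compounds only. Nothing at hand gives a measured reason for the step.

The compounds shown leave open whether the step is particular to chloro or would recur with other groups at this position, such as fluoro, methoxy or an amine. They also leave open whether the same change would read alike on a longer chain.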